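A few compounds are considered here, and "the series" means these few. Any claim that something is new, unique, unknown or untested is made for them only; others in the source may bear on it.

The measured compounds and their values in a functional assay on the whole organism with Rattus norvegicus as the target; on this read-out higher numbers stand for an effect only at larger amounts of compound and lower numbers for an effect already at smaller amounts:

Compound 1, `CCc1c(SC)nc2nc(C(=O)c3ccccc3)cn2c1C`, gives 2 mg/kg.
Compound 2, `CCc1c(OC)nc2nc(C(=O)c3ccccc3)cn2c1CC`, gives 2 mg/kg.
Compound 3, `CSc1cc(C)n2cc(C(=O)c3ccccc3)nc2n1`, gives 5 mg/kg.

Compound 1 and compound 3 differ in a single place: hydrogen in place of ethyl on an aromatic carbon. That change gave a 2.5-fold higher number from compound 1 to compound 3 (0.40 log units; beyond the scatter). Compound 2 stands level with compound 1 at the digits given; how the cores of compound 1 and compound 2 differ is not broken down here.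

Compound 4, `CCc1cn2cc(C(=O)c3ccccc3)nc2nc1OC`, is not yet measured in this assay. It differs from compound 2 in one place: hydrogen in place of ethyl on an aromatic carbon. The surroundings of the spot are not the same as in compound 1, where the spot is ortho to a methyl group, ortho to a methylsulfanyl group, two atoms from the ring nitrogen, meta to a fused ring and para to a fused ring; in compound 2 it is next to the ring nitrogen, ortho to a fused ring, ortho to an ethyl group, meta to a fused ring, meta to a methoxy group and opposite the ring nitrogen. So this is the same kind of change, not the same change.

For compound 4 a step of a 2.5-fold higher number from compound 2 to compound 4 (0.40 log units; beyond the scatter) is expected, resting on the step of a 2.5-fold higher number from compound 1 to compound 3 (0.40 log units; beyond the scatter) seen once with this kind of change. Compound 4 is thus estimated at 5 mg/kg, with a range from 2 mg/kg to 12 mg/kg.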

Compound 4, minimum effective dose: 5 mg/kg
Estimate against measurement, compound 4: no gap at the digits printed, and the stated range covers the measured number.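

In this assay, putting hydrogen in place of ethyl on an aromatic carbon of compound 2 gave a 2.5-fold higher number from compound 2 to compound 4 (0.40 log units; beyond the scatter). Set beside the earlier case, the change carried across to a second core with its size unchanged: the same change on two cores in this assay, a 2.5-fold higher number (0.40 log units; beyond the scatter) from compound 1 to compound 3 and a 2.5-fold higher number (0.40 log units; beyond the scatter) from compound 2 to compound 4, 1.0-fold (0.00 log units) apart, within the scatter of two such steps. This shows that, in these two pairs, losing the ethyl group moved the dose needed for an effect in the same direction and by the same amount, but two pairs do not make a rule for the whole series, and they do not show why the ethyl group matters.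

The compounds shown leave open what other groups would do at this spot on the ring, such as a longer chain like propyl, an amine or a carboxylic acid. From the compounds shown here alone, it also remains open whether the same step would appear on a third core.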